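The source may report more compounds than this note shows. Statements on the series, on what has been measured and on what is new or still open speak of the compounds shown alone.

Measured so far: compound 1 `Cc1nn(-c2ncnc3nc[nH]c23)c2c1C(OC1CCCC1)CC(=O)N2` gives 62 nM; compound 2 `CCCCCCCCOC1CC(=O)Nc2c1c(C)nn2-c1ncnc2nc[nH]c12` gives 388 nM; compound 3 `Cc1nn(-c2ncnc3nc[nH]c23)c2c1C(OCCn1nccc1C)CC(=O)N2` gives 1620 nM.

In a functional assay on HEK293 cells for agonist activity at G-protein coupled receptor 39 (Homo sapiens), read by scintillation proximity assay and inositol phosphate accumulation, with a stated time of 75 min (a higher number here means that more compound is needed for the effect, a lower number that less compound is needed), compound 2 holds the second highest of the three numbers, with a 4.2-fold higher number from compound 2 to compound 3 (0.62 log units; beyond the scatter) and with a 6.3-fold higher number from compound 1 to compound 2 (0.80 log units; beyond the scatter). Compound 4 `Cc1nn(-c2ncnc3nc[nH]c23)c2c1C(OC(=O)c1ccc(F)cc1)CC(=O)N2` differs from compound 2 by (4-fluorophenyl)carbonyl in place of octyl on an oxygen on a saturated carbon. Both measured steps alter the same position and both move the number upward by a modest amount, but neither brings in a (4-fluorophenyl)carbonyl or any aromatic ring of carbon only. The direction for compound 4 therefore rests on a thin basis; a change of modest size in either direction appears plausible. The estimate for compound 4 is 500 nM, between 120 nM and 2500 nM, corresponding to an expected 1.3-fold higher number from compound 2 to compound 4 (0.11 log units; within the scatter).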

Compound 4, half-maximal effective concentration: 245 nM
Compound 4: middle estimate off by 2.0-fold (0.31 log units), on the high side; low and high end bracket the measured number.
By their numbers in this assay, from the lowest: compound 1; then compounds 4 and 2 (each within the scatter of the next); then compound 3.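

In this assay, (4-fluorophenyl)carbonyl brings the first carbonyl and the first aromatic ring of carbon only onto this oxygen, yet its exchange for octyl stays within the scatter, with a 1.6-fold lower number from compound 2 to compound 4 (0.20 log units; within the scatter). The same group remains clearly short of cyclopentyl, with a 4.0-fold higher number from compound 1 to compound 4 (0.60 log units; beyond the scatter), while it clearly improves on the pyrazole-bearing group of compound 3, with a 6.6-fold lower number from compound 3 to compound 4 (0.82 log units; beyond the scatter). No measurement given here accounts for these steps.

As far as these compounds go, whether the carbonyl or the fluorinated ring matters more remains open. So does how a benzyl group, or an octyl chain ending in an amine, would read on this oxygen.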